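Halogen swap on the benzoyl ring of an indole-piperazine series

The source may report more compounds than this note shows. Statements on the series, on what has been measured and on what is new or still open speak of the compounds shown alone.

Measured so far in an ADME assay on HEK293 cells (Homo sapiens) for cytotoxicity, read by MTT assay, with a stated time of 72 h; a lower number here means a stronger inhibitor, a higher number a weaker inhibitor:
Compound 1 `O=C(CN1CCN(C(=O)c2ccc(Br)cc2)CC1)N1CCN(CCCc2c[nH]c3ccccc23)CC1` gives 71900 nM.
Compound 2 `O=C(CN1CCN(C(=O)c2ccc(F)cc2)CC1)N1CCN(CCCc2c[nH]c3ccccc23)CC1` gives 141000 nM.
Compound 3 `COc1ccc2[nH]cc(CCCN3CCN(C(=O)CN4CCN(C(=O)c5cccc(Br)c5)CC4)CC3)c2c1` gives 57000 nM.

Compound 1 and compound 2 share one core and differ by fluoro in place of bromo on an aromatic carbon. That single change produced a 2.0-fold higher number from compound 1 to compound 2 (0.29 log units; within the scatter), so the two values sit within the scatter of each other and no direction can be read from them.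

Compound 3 carries a different core; how the core of compound 3 differs from the core of compound 1 is not broken down here. Compound 3 and compound 1 give numbers within the scatter of each other in this assay, while compound 3 against compound 2 is a gap beyond the scatter.

Compound 4 `COc1ccc2[nH]cc(CCCN3CCN(C(=O)CN4CCN(C(=O)c5cccc(F)c5)CC4)CC3)c2c1` has not yet been measured. It differs from compound 3 by fluoro in place of bromo on an aromatic carbon. This is the same kind of change as that from compound 1 to compound 2, but the place is not identical: in compound 1 to compound 2 the halogen sits "para to a large group", in compound 3 to compound 4 it sits "meta to a large group".

For the measured compounds named here, only one measured example of this change exists, so the expectation for compound 4 rests on compound 1 to compound 2 alone: because that step was a 2.0-fold higher number from compound 1 to compound 2 (0.29 log units; within the scatter), a step of about a 1.8-fold higher number from compound 3 to compound 4 (0.24 log units; within the scatter) is expected, within the scatter. Compound 4 is estimated at 100000 nM, with a range from 45000 nM to 220000 nM, the width reflecting that the change is only shown once and at a different place on the ring.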

Compound 4, half-maximal inhibitory concentration: > 200000 nM
Compound 4: a limit, no number; the forecaster's own chance of this, stated with the estimate: 25%; middle value at least 2.0-fold (0.30 log units) from the limit.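

In this assay compound 4 gives > 200000 nM, which is a limit of the assay and not a number: the limit of > 200000 nM in this assay, at which 1 of the 4 values shown sits.

On the core of compound 3, fluoro in place of bromo on an aromatic carbon gives an at least 3.5-fold higher number from compound 3 to compound 4 (0.54 log units; beyond the scatter), so on this core the change has a readable direction and a size beyond the scatter, whereas the same change on the core of compound 1 stays within the scatter and gives no direction. This does not show that the change carries differently from one core to the other, nor that it carries unchanged, and the size of the step on the core of compound 3 has only a lower bound: the same change on two cores in this assay, a 2.0-fold higher number (0.29 log units; within the scatter) from compound 1 to compound 2 and an at least 3.5-fold higher number (0.54 log units; beyond the scatter) from compound 3 to compound 4; the limit leaves it open whether they differ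

The compounds shown leave open how a chloro or a methyl group in place of the halogen on either core would read in this assay. They also leave open whether any gap between the two steps belongs to the core or to the place on the ring, as the two pairs differ in both.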